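Expected Lipophilicity When Pyridin-3-yl Replaces Dichlorophenyl

The source may report more compounds than this note shows. Statements on the series, on what has been measured and on what is new or still open speak of the compounds shown alone.

Three measured compounds share one core and differ only in the aromatic group on a saturated ring carbon. Compound 1 `O=C(CN1C(=O)c2ccccc2C1=O)NN1C(=O)CSC1c1ccccc1` gives 2.23 in a physicochemical assay for lipophilicity, in phosphate buffer, measured as octanol-water partition, with a stated time of 24 h; on this read-out lower numbers stand for lower lipophilicity and higher numbers for higher lipophilicity. Compound 2 `COc1ccc(C2SCC(=O)N2NC(=O)CN2C(=O)c3ccccc3C2=O)cc1OC` gives 2.78 in this assay, and compound 3 `O=C(CN1C(=O)c2ccccc2C1=O)NN1C(=O)CSC1c1ccc(Cl)cc1Cl` gives 2.54 in this assay. Compound 3 stands second highest of the three, since a number 0.24 log units lower from compound 2 to compound 3 (within the scatter) while a number 0.31 log units higher from compound 1 to compound 3 (beyond the scatter). Compound 4 `O=C(CN1C(=O)c2ccccc2C1=O)NN1C(=O)CSC1c1cccnc1` carries pyridin-3-yl in place of 2,4-dichlorophenyl on a saturated ring carbon. Going by the values given here, no measured step exchanges a carbon-only ring for one with a ring nitrogen, so none bears on this change directly; the only guide is that compound 1 with plain phenyl sits lowest, as a number 0.55 log units higher from compound 1 to compound 2 (beyond the scatter). Compound 4 is therefore expected to fall below every measured value, a number 0.99 log units lower from compound 3 to compound 4 (beyond the scatter), estimated at 1.55 within 1 to 2.1.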

Compound 4, partition coefficient: 1.25
Compound 4: the middle estimate sits 0.30 log units above what was measured; measured number inside the range.
By their numbers in this assay, from the lowest: compound 4; then compound 1; then compounds 3 and 2 (each within the scatter of the next).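

At this saturated ring carbon, an aromatic ring with a ring nitrogen gives the lowest number of the series in this assay. Pyridin-3-yl falls well below both substituted rings (a number 1.29 log units lower from compound 3 to compound 4 (beyond the scatter); a number 1.53 log units lower from compound 2 to compound 4 (beyond the scatter)). It also falls below plain phenyl (a number 0.98 log units lower from compound 1 to compound 4 (beyond the scatter)), so the ring nitrogen alone, with no chlorine or methoxy groups involved in the step, moves the number beyond the scatter. On these data alone, whether an amine or a carboxylic acid on the phenyl ring would lower the number as far remains open. Nothing available here explains the size of this drop.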